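Trifluoromethoxy in place of chloro on compound 2

A few compounds are considered here, and "the series" means these few. Any claim that something is new, unique, unknown or untested is made for them only; others in the source may bear on it.

compound 1 `CNC(=O)c1ccc(Sc2ccc(NC(=S)Nc3cccc(C)c3)cc2)nc1` gives > 100000 nM as a limit
compound 2 `CNC(=O)c1ccc(Sc2ccc(NC(=S)Nc3ccc(Cl)cc3)cc2)nc1` gives 69300 nM

For the measured compounds named here, both compounds were tested in a functional assay on B16-BL6 cells (Mus musculus) for cytotoxicity, read by MTT assay, with a stated time of 48 h (on this read-out lower numbers stand for stronger inhibition and higher numbers for weaker inhibition), and compound 2 gives 69300 nM as the only actual number in the set. Compound 1 reads > 100000 nM and that is a limit, not a number. Going by the values given here, the same limit appears as the limit of > 100000 nM in this assay, at which 1 of the 2 values shown sits, and marks the only other point of comparison.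

The next compound is compound 3 `CNC(=O)c1ccc(Sc2ccc(NC(=S)Nc3ccc(OC(F)(F)F)cc3)cc2)nc1` with trifluoromethoxy in place of chloro on an aromatic carbon, para to a large group. The change is counted as trifluoromethoxy in place of chloro on an aromatic carbon and the rest of the structure stays the same.

Among the compounds with values here, only one measured step bears on it, and that step concerns a different pair of groups at the same ring: an at least 1.4-fold lower number from compound 1 to compound 2 (0.15 log units; that floor lies within the scatter) gives a floor and no firm size. No step beyond the scatter is therefore expected in this assay in either direction. The expected step is a 1.2-fold lower number from compound 2 to compound 3 (0.06 log units; within the scatter) and it rests on compound 2 at 69300 nM as the starting point. Compound 3 is estimated at 60000 nM with an expected range from 25000 nM to 120000 nM.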

Compound 3, half-maximal inhibitory concentration: > 100000 nM
Compound 3 ended at the assay's limit; the forecaster's own chance of this, stated with the estimate: 30%; middle value at least 1.6-fold (0.22 log units) away from the limit.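

In this assay compound 3 reads > 100000 nM, and that is a limit, not a number. Trifluoromethoxy in place of chloro on an aromatic carbon, para to a large group, gives an at least 1.4-fold higher number from compound 2 to compound 3 (0.15 log units; that floor lies within the scatter), so this step too has a floor and no firm size, and it cannot say whether the two groups truly differ at this position. Unlike the earlier step, which changed both the group and where it sat, this one changes only the group at a fixed place, and swapping one heavy atom for 5 heavy atoms, with 1 hydrogen-bond acceptor added, does not yield a second actual number, leaving compound 2 as the only compound in the set that has one: the limit of > 100000 nM in this assay, at which 2 of the 3 values shown sit.

Going by these compounds, how far compound 3 lies past the limit stays open, and with it whether chloro holds any real edge over trifluoromethoxy at this position. Also open, on these data alone, is how a methoxy group, an amine or a carboxylic acid on the same aromatic carbon would read in this assay, and whether any of them would give a number clearly apart from that of compound 2.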